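This account rests on a few compounds, and the source may have more. Where it says the series, first, only, none or still open, it means among the compounds named here.

Working notes on the series, in an assay on isolated protein for inhibition of advanced glycosylation end product-specific receptor (Homo sapiens), read by FRET, with stated times of 30 min and 1 h, tested at 4 uM; on this read-out lower numbers stand for less inhibition and higher numbers for more inhibition at the one concentration tested (going by the name of the read-out).

Compound 1 `CN1CCC(Oc2ccc(-c3nc4ccc(Oc5ccc(Cl)cc5)cc4o3)cc2)CC1` gives 19.5% in this assay, compound 2 `CCN1CCC(Oc2ccc(-c3nc4ccc(Oc5ccc(Cl)cc5)cc4o3)cc2)CC1` gives 15.3%, and compound 3 `Clc1ccc(Oc2ccc3nc(-c4ccc(OCCCN5CCCCC5)cc4)oc3c2)cc1` gives 2.2%, the lowest of the three; the nearest is compound 2, and the steps of a number 17.3 percentage points lower from compound 1 to compound 3 (beyond the scatter) and a number 13.1 percentage points lower from compound 2 to compound 3 (beyond the scatter) both exceed the scatter, while a number 4.2 percentage points lower from compound 1 to compound 2 (within the scatter) does not.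

Compound 4 `CN1CCN(CCCOc2ccc(-c3nc4ccc(Oc5ccc(Cl)cc5)cc4o3)cc2)CC1` differs from compound 3 in the amine at the end of the chain: 4-methylpiperazin-1-yl in place of piperidin-1-yl on a saturated chain carbon, three bonds along the chain from an oxygen on an aromatic ring. Among the compounds with values here, no measured step exchanges one amine ring for another on this chain; the two steps that reach compound 3 alter the whole chain and are modest. For compound 4 no step beyond the scatter is therefore expected, a number 1.8 percentage points higher from compound 3 to compound 4 (within the scatter). Compound 4 is thus estimated at 4%, between -6% and 15%.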

Compound 4, a percentage reported as inhibition, at one concentration (the size of the read-out at that concentration, not a potency): 24.3%
Compound 4: the middle estimate sits 20.3 percentage points below what was measured, and the stated range ends below it.
By their numbers in this assay, from the lowest: compound 3; then compounds 2, 1 and 4 (each within the scatter of the next).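

On a saturated chain carbon, three bonds along the chain from an oxygen on an aromatic ring, changing only the amine ring moves the number in this assay: 4-methylpiperazin-1-yl in place of piperidin-1-yl gives a number 22.1 percentage points higher from compound 3 to compound 4 (beyond the scatter). The propyl chain itself therefore does not fix the low number, since the 3-(4-methylpiperazin-1-yl)propyl group gives a number 9 percentage points higher from compound 2 to compound 4 (within the scatter) and a number 4.8 percentage points higher from compound 1 to compound 4 (within the scatter). No available measurement accounts for this step.

Going by these compounds, it remains open whether morpholine or unsubstituted piperazine on the same propyl chain would follow compound 3 or compound 4. On these data alone, a longer chain carrying 4-methylpiperazin-1-yl is equally open.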